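Thiophene substituent trimming in a bornane-amine cytotoxicity series

A few compounds are considered here, and "the series" means these few. Any claim that something is new, unique, unknown or untested is made for them only; others in the source may bear on it.

This account follows a small series of bornane-derived amines in an ADME assay on MDCK cells (Canis lupus familiaris) for cytotoxicity, read by microscopy, with a stated time of 48 h; on this read-out lower numbers stand for higher toxicity in this test and higher numbers for lower toxicity in this test. Compound 1 `C[C@H]1[C@H](NCc2cc(C3CC3)cs2)C[C@H]2C[C@@H]1C2(C)C` gives 25000 nM. Compound 2 `C=C(C)c1csc(CN[C@@H]2C[C@H]3C[C@@H]([C@H]2C)C3(C)C)c1` gives 25000 nM, and compound 3 `CCc1ccsc1CN[C@@H]1C[C@H]2C[C@@H]([C@H]1C)C2(C)C` gives 25000 nM; compound 1 therefore stands level with both at the digits shown. Going by the values given here, the only measured step that speaks to changing the group on the aromatic carbon, no change at the digits printed from compound 1 to compound 2 (within the scatter), lay within the scatter. Compound 4 `C[C@H]1[C@H](NCc2cccs2)C[C@H]2C[C@@H]1C2(C)C` differs from compound 1 by hydrogen in place of cyclopropyl on an aromatic carbon. Among the compounds with values here, with one flat step as the sole guide, no change beyond the scatter is expected in this assay from compound 1 to compound 4, that is no change at the digits printed from compound 1 to compound 4 (within the scatter). Compound 4 is accordingly estimated at 25000 nM, within 12500 nM to 50000 nM.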

Compound 4, minimum cytotoxic concentration: 25000 nM
Compound 4: the middle estimate sits on the measured number at the digits printed, and the stated range covers the measured number.
By their numbers in this assay, from the lowest: compounds 1, 2, 3 and 4 (each within the scatter of the next).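

In this assay removing the group altogether proves as flat as exchanging it, with no change at the digits printed from compound 1 to compound 4 (within the scatter) for hydrogen in place of cyclopropyl and no change at the digits printed from compound 2 to compound 4 (within the scatter) for hydrogen in place of 1-methylethenyl. Hydrogen in place of ethyl likewise gives no change at the digits printed from compound 3 to compound 4 (within the scatter) and so no carbon substituent on the aromatic ring is needed for this level among these four compounds. From the compounds shown here alone, whether an amine or a carboxylic acid on that ring would shift the read-out stays open. Nothing shown explains why these steps are flat.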